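The compounds below may be only part of what the source reports. "The series", "measured", "known", "first", "only" and "open" are said of these compounds alone.

Compound 1 `COc1cc(-c2nn(-c3cccc(NC(=O)c4cccc(C(F)(F)F)c4)c3)cc2-c2ccncc2)ccc1Cl`: 3150 nM; compound 2 `O=C(Nc1cccc(-n2cc(-c3ccncc3)c(-c3ccc(Cl)c(O)c3)n2)c1)Nc1cc(C(F)(F)F)cc(C(F)(F)F)c1`: 2490 nM.

In a functional assay on RXF 393 cells (Homo sapiens) for inhibition, read by sulforhodamine B assay, with a stated time of 48 h (a higher number here means a weaker inhibitor of growth, a lower number a stronger inhibitor of growth), compound 1 holds the higher of the two numbers, with compound 2 within the scatter of it. Compound 3 `COc1cc(-c2nn(-c3cccc(NC(=O)Nc4ccc(Cl)c(Cl)c4)c3)cc2-c2ccncc2)ccc1Cl` differs from compound 1 by (3,4-dichlorophenyl)amino in place of 3-(trifluoromethyl)phenyl on a carbonyl carbon. For the measured compounds named here, no measured pair shows this exact change, but compound 2 also carries a carbamoyl link and gives 2490 nM, close to compound 1. The step expected is a 1.3-fold lower number from compound 1 to compound 3 (0.10 log units; within the scatter), not beyond the scatter. Compound 3 is therefore estimated at 2500 nM, within 800 nM to 8000 nM.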

Compound 3, concentration for total growth inhibition: 2440 nM
Compound 3: the middle estimate sits 1.0-fold (0.01 log units) above what was measured; the measured number falls inside the stated range.
By their numbers in this assay, from the lowest: compounds 3, 2 and 1 (each within the scatter of the next).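

In this assay, (3,4-dichlorophenyl)amino in place of 3-(trifluoromethyl)phenyl on a carbonyl carbon gives a 1.3-fold lower number from compound 1 to compound 3 (0.11 log units; within the scatter). For the compounds shown here, this is the first direct one-place comparison at this position, and it shows that the added hydrogen-bond donor and the swapped ring substituents together leave the number within the scatter. Nothing available explains this outcome.

Going by these compounds alone, the single step cannot separate the effect of the amino link from that of the two chlorines. On these data alone, whether a piperidine or a carboxylic acid on this carbonyl carbon would move the number beyond the scatter remains open.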